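Morpholine for pyrrolidine on the thiocarbonyl carbon

The source may hold more compounds than are shown below. What is called first, only, known or untested is meant among the compounds shown, and "the series" means these compounds.

Three compounds in the series have numbers in a functional assay on MCF7 cells (Homo sapiens) for cytotoxicity, read by MTT assay, with a stated time of 72 h, tested at 10 uM; a higher number here means more inhibition of growth at the concentration tested, a lower number less inhibition of growth. Compound 1 `N/C(=N\NC(=S)N1CCCC1)c1ccc(F)cn1` gives 54.5%. Compound 3 `Cc1ccnc(/C(N)=N/NC(=S)N2CCCCCC2)c1` gives 60.3%. Compound 2 `Cc1cccc(/C(N)=N/NC(=S)N2CCSCC2)n1` gives 22.5%. Compound 1 stands second highest of the three: within the scatter of compound 3, and beyond the scatter above compound 2. Compounds 2 and 3 each differ from compound 1 in more than one place, so no single-change step can be read from the measured pairs.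

Compound 4 `N/C(=N\NC(=S)N1CCOCC1)c1ccc(F)cn1` is the next to be measured. It differs from compound 1 by morpholin-4-yl in place of pyrrolidin-1-yl on a thiocarbonyl carbon. Among the measured compounds shown here, no measured pair shows this change, so its size is open; the measured numbers only show that the ring on the thiocarbonyl carbon can be varied with compound 1 at 54.5% and compound 3 at 60.3% remaining within the scatter of each other, while compound 2 lies clearly lower. The expected step, a number 12.5 percentage points lower from compound 1 to compound 4 (beyond the scatter), is a modest lowering, with a result inside the scatter of compound 1 also plausible. Compound 4 is estimated at 42% in this assay, with a range of 22% to 60%.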

Compound 4, percent growth inhibition at one concentration: 39.5%
Beside the measured number, compound 4's estimate is 2.5 percentage points above it; the measured number falls inside the stated range.
By their numbers in this assay, from the lowest: compound 2; then compound 4; then compounds 1 and 3 (each within the scatter of the next).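

In this assay, among the compounds shown here, the series now has its only single-change step: morpholin-4-yl in place of pyrrolidin-1-yl on a thiocarbonyl carbon gives a number 15 percentage points lower from compound 1 to compound 4 (beyond the scatter). On the core of compound 1, the ring at this position therefore affects the read-out, and this exchange takes the number beyond the scatter. No measurement at hand accounts for the size of this step.

The exchange changes the ring from five-membered to six-membered and also adds an oxygen, so this one step cannot separate those two changes; piperidin-1-yl on the core of compound 1 would divide them. From the compounds shown here alone, whether the same exchange gives a step of similar size on other cores also remains open.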